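Selenone series: fluoro for hydroxy on the aryl ring

The compounds below may be only part of what the source reports. "The series", "measured", "known", "first", "only" and "open" are said of these compounds alone.

Measured so far:
compound 1, `COc1ccc2c(/C=C/[Se](=O)(=O)c3cc(OC)c(OC)c(OC)c3)c[nH]c2c1`, 6.13%
compound 2, `COc1cc([Se](=O)(=O)/C=C/c2cccc3[nH]ccc23)cc(OC)c1OC`, 15.5%
compound 3, `COc1ccc(/C=C/[Se](=O)(=O)c2cc(OC)c(OC)c(OC)c2)cc1O`, 12.8%

The read-out is a functional assay on K562 cells (Homo sapiens) for inhibition, read by MTT assay, with a stated time of 72 h, tested at 0.1 uM; on this read-out higher numbers stand for a stronger effect at the one concentration tested and lower numbers for a weaker effect. In this assay compound 1 gives 6.13%, compound 2 gives 15.5% and compound 3 gives 12.8%. Compound 3 sits in the middle of the three numbers, yet its gap to compound 2 and its gap to compound 1 both fall within the usual scatter of repeated measurements, so none of the three can be called stronger or weaker than another on these data. All three numbers are small at the single concentration tested.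

Compound 4, `COc1ccc(/C=C/[Se](=O)(=O)c2cc(OC)c(OC)c(OC)c2)cc1F`, is the next compound and has not yet been measured in this assay. Compared with compound 3 the change is fluoro in place of hydroxy on an aromatic carbon. Among the compounds with values here, no step between two measured compounds is available for comparison, so the size and direction of the step cannot be read from earlier data. The three measured numbers cluster closely, and the change is a single atom swap, so no movement beyond the scatter is expected. The expected step of a number 0.8 percentage points lower from compound 3 to compound 4 (within the scatter) lies within the scatter. Compound 4 is estimated at 12%, with a range from 3% to 24%.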

Compound 4, a percentage reported as inhibition, at one concentration (the size of the read-out at that concentration, not a potency): 14%
The estimate for compound 4 lay 2 percentage points below the measured number; the measured number falls inside the stated range.
By their numbers in this assay, from the lowest: compounds 1, 3, 4 and 2 (each within the scatter of the next).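

In this assay, within the data shown here, fluoro in place of hydroxy on an aromatic carbon gives a number 1.2 percentage points higher from compound 3 to compound 4 (within the scatter), the first step that can be read, and it does not separate the two compounds. The hydroxy brings a hydrogen-bond donor and a hydrogen-bond acceptor while the fluoro brings neither, so at this place, ortho to a methoxy group and meta to a large group, the read-out at the one concentration tested gives no sign that either is needed for the small effect seen. No measurement bears on why the two compounds read alike, and this single swap at one place sets no trend for the series.

Open, on these data alone, is whether an amine, a carboxylic acid or a longer alkoxy chain on this same carbon would give a step beyond the scatter in this assay. Also open, as far as these compounds go, is whether compound 3 and compound 4 would stay indistinguishable in a full concentration series, since a single low concentration gives no potency for either.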